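This account rests on a few compounds, and the source may have more. Where it says the series, first, only, none or still open, it means among the compounds named here.

The measured compounds:

compound 1, `CC(C)(C)CC(C)(C)c1ccc(OCC(=O)Nc2ccc(C(F)(F)F)cc2)cc1`, 1530 nM
compound 2, `COC(=O)c1cccc(NC(=O)COc2ccc(C)cc2)c1`, > 40000 nM
compound 3, `COC(=O)c1ccc(O)c(NC(=O)CCOc2ccc(C(C)(C)CC(C)(C)C)cc2)c1`, 4600 nM

All three were tested in an assay on isolated protein for inhibition of malate dehydrogenase, mitochondrial (Homo sapiens), with a stated time of 30 min; a lower number here means a stronger inhibitor, a higher number a weaker inhibitor. Compound 1 gives 1530 nM and compound 3 gives 4600 nM; both carry the same large branched alkyl group on the outer ring. Compound 2 stands apart: its result, > 40000 nM, is not a number but a limit of this assay. It sits at the limit of > 40000 nM in this assay, at which 1 of the 3 values shown sits, so only an upper bound on its weakness is known, and no exact figure.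

Compound 4, `COC(=O)c1cccc(NC(=O)COc2ccc([N+](=O)[O-])cc2)c1`, has not yet been measured in this assay. It differs from compound 2 in one place: nitro in place of methyl on an aromatic carbon. Within the data shown here, since no pair of measured compounds differs in exactly one spot, there is no measured step to lean on, and the two compounds that do give numbers, compound 1 and compound 3, carry a quite different outer group.

Without such a guide, the expectation for compound 4 rests on compound 2 alone, whose result in this assay is a limit. Compound 4 is estimated at 30000 nM, within a range from 8000 nM to 100000 nM. The expected step is an at least 1.3-fold lower number from compound 2 to compound 4 (0.12 log units; that floor lies within the scatter), and a limit rather than a number remains quite possible.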

Compound 4, half-maximal inhibitory concentration: > 40000 nM
Compound 4: a limit, no number; the forecaster's own chance of this, stated with the estimate: 55%; middle value at least 1.3-fold (0.12 log units) away from the limit.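

Among these compounds, compound 2 and compound 4 both end at a limit of this assay rather than at a number, so the change from methyl to nitro gives no step that can be read: the limit of > 40000 nM in this assay, at which 2 of the 4 values shown sit. The compounds shown leave open whether nitro in place of methyl alters inhibition at all, and how compound 2 and compound 4 rank against each other.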